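Anilide variation on the shared core: compound 4

This account rests on a few compounds, and the source may have more. Where it says the series, first, only, none or still open, it means among the compounds named here.

Measured so far in a functional assay on HEK293 cells for agonist activity at D(4) dopamine receptor (Homo sapiens), read by FLIPR; on this read-out higher numbers stand for an effect only at larger amounts of compound and lower numbers for an effect already at smaller amounts:
compound 1, `CCc1cccc(NC(=O)CN2CCC(c3cccc[n+]3[O-])CC2)c1`: 95 nM
compound 2, `O=C(CN1CCC(c2cccc[n+]2[O-])CC1)Nc1cccc(F)c1`: 160 nM
compound 3, `O=C(CN1CCC(c2cccc[n+]2[O-])CC1)Nc1ccc(F)cc1F`: 103 nM

On the numbers shown compound 3 gives the second highest of three, but neither a 1.1-fold higher number from compound 1 to compound 3 (0.04 log units; within the scatter) nor a 1.6-fold lower number from compound 2 to compound 3 (0.19 log units; within the scatter) goes beyond the scatter, so the three anilides are not separated. Compound 4, `O=C(CN1CCC(c2cccc[n+]2[O-])CC1)Nc1cccc(Cl)c1Cl`, differs from compound 3 as follows: 2,3-dichlorophenyl in place of 2,4-difluorophenyl on an amide-type nitrogen. Going by the values given here, the steps that bear on this are the three aryl exchanges on the amide-type nitrogen, a 1.7-fold higher number from compound 1 to compound 2 (0.23 log units; within the scatter), a 1.1-fold higher number from compound 1 to compound 3 (0.04 log units; within the scatter) and a 1.6-fold lower number from compound 2 to compound 3 (0.19 log units; within the scatter), all within the scatter. Among the compounds with values here, no measured step introduces chlorine or the 2,3-dichlorophenyl pattern, so the expectation is a step of about a 1.1-fold higher number from compound 3 to compound 4 (0.03 log units; within the scatter), nothing beyond the scatter. Compound 4 is estimated at 110 nM, range 40 nM to 320 nM.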

Compound 4, half-maximal effective concentration: 180 nM
Beside the measured number, compound 4's estimate is 1.6-fold (0.21 log units) below it; the range from low to high includes it.
By their numbers in this assay, from the lowest: compounds 1, 3, 2 and 4 (each within the scatter of the next).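

Chlorine now appears on the aryl group on the amide-type nitrogen, and in this assay the 2,3-dichlorophenyl exchange stays within the scatter on all three new steps: a 1.7-fold higher number from compound 3 to compound 4 (0.24 log units; within the scatter) and a 1.1-fold higher number from compound 2 to compound 4 (0.05 log units; within the scatter) and a 1.9-fold higher number from compound 1 to compound 4 (0.28 log units; within the scatter) are the whole of it. The four aryl groups at this position are therefore not separated by these numbers. No measurement bears on any reason for this.

From the compounds shown here alone, whether an aryl group carrying an amine or a carboxylic acid would move the number beyond the scatter remains open. So does the effect of a longer alkyl chain in place of the aryl group on this nitrogen.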